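Swapping Methoxy for Nitro on a Morpholine Ether Series

A few compounds are considered here, and "the series" means these few. Any claim that something is new, unique, unknown or untested is made for them only; others in the source may bear on it.

Of the compounds shown here, three sharing one core have been measured in an assay on membranes from brain for displacement of a labelled ligand from Norepinephrine transporter (Rattus norvegicus); on this read-out lower numbers stand for stronger inhibition and higher numbers for weaker inhibition. Compound 1, `COc1ccccc1COC(c1cccc(I)c1)C1CNCCO1`, gives 73.8 nM in this assay. Compound 2, `CCOc1ccccc1OC(c1cccc(I)c1)C1CNCCO1`, gives 28.5 nM in this assay, a number lower than that of compound 1 by a gap beyond the usual scatter. Compound 3, `Cc1ccccc1OC(c1ccc(I)s1)C1CNCCO1`, gives 71.9 nM in this assay, a number that sits within the scatter of compound 1. Compound 1 therefore has the highest of the three numbers, and only compound 2 is clearly separated from it.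

Compound 4, `O=[N+]([O-])c1ccccc1COC(c1cccc(I)c1)C1CNCCO1`, is still to be measured. It differs from compound 1 in one place: nitro in place of methoxy on an aromatic carbon. Going by the values given here, no measured pair in this set shows the effect of such a swap, so nothing in the data points to a direction. The step from compound 1 to compound 4 is expected to be small, likely no larger than the scatter, as a 1.1-fold higher number from compound 1 to compound 4 (0.04 log units; within the scatter). Compound 4 is thus estimated at 80 nM in this assay, with a plausible range from 25 nM to 250 nM.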

Compound 4, inhibition constant: 70.4 nM
Estimate against measurement, compound 4: 1.1-fold (0.06 log units) above, within the range that was stated.
By their numbers in this assay, from the lowest: compound 2; then compounds 4, 3 and 1 (each within the scatter of the next).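

In this assay, exchanging methoxy for nitro, ortho to a large group, is recorded as a 1.0-fold lower number from compound 1 to compound 4 (0.02 log units; within the scatter), so the two compounds cannot be told apart on this read-out. Going by these compounds alone, this is the first direct view of this position: two groups that differ in their atoms and in their count of hydrogen-bond acceptors are not separated here, at least for this one pair. No separate measurement bears on this result.

A single swap cannot show whether other groups at this position, such as an amine or a carboxylic acid, would also stay within the scatter of compound 1. It also leaves open whether the same swap would give a similarly small step on a core other than that of compound 1.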